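A few compounds are considered here, and "the series" means these few. Any claim that something is new, unique, unknown or untested is made for them only; others in the source may bear on it.

In a functional assay on A549 cells (Homo sapiens) for cytotoxicity, read by colorimetric assay and MTT assay, with a stated time of 3 days, tested at 20 uM (on this read-out higher numbers stand for a weaker effect at the one concentration tested and lower numbers for a stronger effect), compound 2 `O=C1COc2ccc(-c3[nH]c(-c4ccc(F)cc4)nc3-c3ccccc3)cc2N1` gives 37.5%, the second highest of the three numbers shown. Within the data shown here, compound 1 `O=C1COc2ccc(-c3[nH]c(-c4ccc(C(F)(F)F)cc4)nc3-c3ccccc3)cc2N1` gives 21.7%, and the one single-place step, a number 15.8 percentage points higher from compound 1 to compound 2 (beyond the scatter), runs toward a weaker effect. Compound 3 `O=C1COc2ccc(-c3nn(-c4ccc(Cl)cc4)cc3-c3ccccc3)cc2N1` gives 52.4%; it differs from compound 2 in more than one place, so its number is simply noted. Compound 4 `O=C1COc2ccc(-c3[nH]c(-c4c[nH]c5ncccc45)nc3-c3ccccc3)cc2N1` has not been measured; it carries a group of 9 heavy atoms (7 carbon, 2 nitrogen; one five-membered aromatic ring with 1 hetero atom, one six-membered aromatic ring with 1 hetero atom) in place of a group of 7 heavy atoms (6 carbon, 1 fluorine; one six-membered aromatic ring of carbon only), on an aromatic carbon. Among the measured compounds shown here, no measured step bears on this change: the only known step exchanges one substituent on an aromatic carbon, whereas here a group of 7 heavy atoms gives way to one of 9 heavy atoms. The expectation therefore rests on compound 2 alone, with wide uncertainty. Compound 4 is expected to give 45% (from 20% to 75%), an expected step of a number 7.5 percentage points higher from compound 2 to compound 4 (within the scatter) that may not exceed the scatter.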

Compound 4, a percentage reported as activity, at one concentration (the size of the read-out at that concentration, not a potency): 86.8%
Estimate against measurement, compound 4: 41.8 percentage points below; the measured number lies above the stated range.
By their numbers in this assay, from the lowest: compound 1; then compound 2; then compound 3; then compound 4.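

At this position on the aromatic carbon between two ring nitrogen atoms, the change of group can cost far more of the effect than the earlier exchange of substituents on the phenyl ring did: a number 49.3 percentage points higher from compound 2 to compound 4 (beyond the scatter) in this assay. The step is larger still starting from the trifluoromethyl analogue, a number 65.1 percentage points higher from compound 1 to compound 4 (beyond the scatter), so both para-substituted phenyl compounds keep more effect than the entering group allows. Nothing measured explains this loss. The compounds shown leave open how an unsubstituted phenyl or a pyridyl group would behave here, and so which feature of the entering group matters.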